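The source may hold more compounds than are shown below. What is called first, only, known or untested is meant among the compounds shown, and "the series" means these compounds.

Measured so far in a functional assay on HL-60 cells (Homo sapiens) for antiproliferative activity, read by MTT assay, with a stated time of 72 h; a higher number here means a weaker inhibitor, a lower number a stronger inhibitor
compound 1 `NC1=NC2(CCSCC2)N(OCCCOc2cccc(Cl)c2)C(N)=N1` gives 260 nM
compound 2 `NC1=NC2(CCOCC2)N(OCCCOc2ccc(F)cc2)C(N)=N1` gives 2380 nM
compound 3 `NC1=NC2(CCOCC2)N(OCCCOc2cccc(Cl)c2)C(N)=N1` gives 520 nM

Compound 1 and compound 3 lie within the usual scatter of each other, so the data do not separate them. Compound 2 carries a clearly higher number than either, which puts compound 1 in the better pair of the three.

The next analogue is compound 4 `NC1=NC2(CCSCC2)N(OCCCOc2cccc(Br)c2)C(N)=N1` and its difference from compound 1 is bromo in place of chloro on an aromatic carbon with bromo in place of chloro on an aromatic carbon, meta to a large group. The same difference reads 3-chlorophenyl to 3-bromophenyl.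

For the measured compounds named here, only one measured step touches this phenyl group. With 3-chlorophenyl in place of 4-fluorophenyl the series shows a 4.6-fold lower number from compound 2 to compound 3 (0.66 log units; beyond the scatter) and this modest step changes both the halogen and its place on the ring. It therefore offers only weak guidance for a swap that leaves the place unchanged. Going by the values given here, no measured step exchanges chloro for bromo, so the value of compound 1 remains the main anchor. The expected step is a 1.1-fold lower number from compound 1 to compound 4 (0.03 log units; within the scatter) and no shift beyond the scatter is expected. Compound 4 is estimated at 240 nM in this assay with an expected range from 110 nM to 520 nM for repeated measurements.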

Compound 4, half-maximal inhibitory concentration: 200 nM
Compound 4: the middle estimate sits 1.2-fold (0.08 log units) above what was measured; the measured number falls inside the stated range.
By their numbers in this assay, from the lowest: compounds 4, 1 and 3 (each within the scatter of the next, the first and the last beyond it); then compound 2.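

In this assay, bromo in place of chloro on the aromatic carbon, meta to a large group, gives a 1.3-fold lower number from compound 1 to compound 4 (0.11 log units; within the scatter), so the data do not separate these two halogens at this place. For the compounds shown here, the earlier step, a 4.6-fold lower number from compound 2 to compound 3 (0.66 log units; beyond the scatter), changed both the halogen and its place on the ring, whereas this one keeps the place fixed and exchanges only chloro for bromo, and it gives the first reading of the halogen alone. No measurement shown here bears on the result, so the two halogens reading alike stays a plain observation without an explanation.

The compounds shown leave open whether a group other than a halogen at this place, such as methoxy, trifluoromethyl, a nitrile or an amine, would stay within the scatter of compound 4 or move beyond it. They also leave open whether the 3-bromophenyl group would read the same on the core of compound 3, and what a longer chain in place of the 3-bromophenoxy group would do in this assay.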